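Swapping Methoxy for Bromo on a Shared Core

This account rests on a few compounds, and the source may have more. Where it says the series, first, only, none or still open, it means among the compounds named here.

In a functional assay on A549 cells (Homo sapiens) for cytotoxicity, with a stated time of 48 h (a lower number here means a stronger inhibitor, a higher number a weaker inhibitor), compound 2 `COc1ccc2oc(/C=C/[S+](C)[O-])cc(=O)c2c1` gives 1600 nM and stands within the scatter of compound 1 `CCCC(=O)Oc1ccc2oc(/C=C/[S+](C)[O-])cc(=O)c2c1` at 2200 nM so neither can be ranked over the other. Compound 3 `C[S+]([O-])/C=C/c1cc(=O)c2cc(Br)ccc2o1` carries bromo in place of methoxy on an aromatic carbon and otherwise keeps the core of compound 2. Among the compounds with values here, only one measured step offers guidance: replacing propylcarbonyl with methyl on an oxygen on an aromatic ring gave a 1.4-fold lower number from compound 1 to compound 2 (0.14 log units; within the scatter) and so stayed within the scatter. Within the data shown here, no measured compound carries bromo, which leaves the direction open, and no change beyond the scatter is expected in this assay for this swap. The estimate amounts to a 1.1-fold lower number from compound 2 to compound 3 (0.03 log units; within the scatter) as the expected step. For compound 3 the estimated value is 1500 nM with an expected range from 600 nM to 3800 nM in repeated measurements.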

Compound 3, half-maximal inhibitory concentration: 1100 nM
Estimate against measurement, compound 3: 1.4-fold (0.13 log units) above; low and high end bracket the measured number.
By their numbers in this assay, from the lowest: compounds 3, 2 and 1 (each within the scatter of the next).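

This place on the aromatic ring now shows a third kind of group, and in this assay the swap from methoxy to bromo, which has one heavy atom and no hydrogen-bond acceptor, gives a 1.5-fold lower number from compound 2 to compound 3 (0.16 log units; within the scatter). The wider comparison with the (propylcarbonyl)oxy group gives a 2.0-fold lower number from compound 1 to compound 3 (0.30 log units; within the scatter), so all three groups remain unranked, and compound 3 shows that a number of this size does not depend on an oxygen attached at this carbon. Nothing available explains why the three numbers lie so close together.

Going by these compounds, whether an amine, a carboxylic acid or a longer chain at this carbon would move the number beyond the scatter remains open. Also open, on these data alone, is whether bromo would give a similar result with other changes to the shared core.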